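The compounds below may be only part of what the source reports. "The series", "measured", "known", "first", "only" and "open" are said of these compounds alone.

Among the compounds with values here, compound 2 `COc1ccc(C(=O)/C=C/c2cc(-c3cc(OC)c(OC)c(OC)c3)n[nH]2)cc1OC` gives the lowest of the two numbers measured so far: in a functional assay on MCF7 cells (Homo sapiens) for inhibition, read by sulforhodamine B assay, with a stated time of 48 h (a higher number here means a weaker inhibitor of growth, a lower number a stronger inhibitor of growth), compound 2 gives 1950 nM, while compound 1 `COc1cc(-c2cc(/C=C/C(=O)c3ccc(N)cc3)[nH]n2)cc(OC)c1OC` gives 5420 nM. That difference, a 2.8-fold lower number from compound 1 to compound 2 (0.44 log units; beyond the scatter), came from one change on the carbonyl carbon. Compound 3 `COc1cc(-c2cc(/C=C/C(=O)c3ccc(F)c(F)c3)[nH]n2)cc(OC)c1OC` differs from compound 2 by 3,4-difluorophenyl in place of 3,4-dimethoxyphenyl on a carbonyl carbon. Within the data shown here, no measured step swaps these two groups, so the one step only shows that this position shifts the number modestly. For compound 3 a small rise is expected, a 1.8-fold higher number from compound 2 to compound 3 (0.25 log units; within the scatter), giving an estimate of 3500 nM within 1200 nM to 10000 nM.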

Compound 3, concentration for total growth inhibition: 12300 nM
Estimate against measurement, compound 3: 3.5-fold (0.55 log units) below; measured number above the stated range.
By their numbers in this assay, from the lowest: compound 2; then compound 1; then compound 3.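

Swapping in 3,4-difluorophenyl on the carbonyl carbon shows that this position can also raise the number, and by more than the first step lowered it: there is a 6.3-fold higher number from compound 2 to compound 3 (0.80 log units; beyond the scatter), and even against the 4-aminophenyl group there is a 2.3-fold higher number from compound 1 to compound 3 (0.36 log units; beyond the scatter). Compound 3 is therefore the weakest growth inhibitor of the three, with compound 2 the strongest. Nothing available explains this order. Still open, on these data alone, is where a plain phenyl group or a phenyl group carrying a single methoxy or a single fluorine would fall.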